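This account rests on a few compounds, and the source may have more. Where it says the series, first, only, none or still open, it means among the compounds named here.

Compound 1 `CCC/N=C1\S/C(=C\c2ccc(O)c(Cl)c2)C(=O)N1c1ccccc1C` and compound 2 `CCC/N=C1\S/C(=C\c2ccc(O)c(Cl)c2)C(=O)N1c1ccccc1OC` share one core and differ only in a methoxy in place of methyl on an aromatic carbon. In a physicochemical assay for solubility, measured as kinetic solubility (a higher number here means a more soluble compound, a lower number a less soluble compound), compound 1 gives 79000 nM, and compound 2 gives 79000 nM, so the step of no change at the digits printed from compound 1 to compound 2 (within the scatter) is flat. Among the compounds with values here, compound 1 thus stands level with compound 2, the only other compound measured so far.

Compound 3 `Cc1ccccc1N1C(=O)/C(=C/c2ccc(O)c(Cl)c2)S/C1=N\CCO` differs from compound 1 in another place: hydroxy in place of methyl on a saturated chain carbon, two bonds along the chain from a double-bonded nitrogen. Within the data shown here, the one measured step, from compound 1 to compound 2, concerns a different position and a different pair of groups, so no measured step bears on this change, and nothing in the data shows how a hydroxy on the chain shifts this assay. With that gap, compound 3 is expected to lie near compound 1, at an estimated 100000 nM with a range from 40000 nM to 250000 nM, an expected step of a 1.3-fold higher number from compound 1 to compound 3 (0.10 log units; within the scatter).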

Compound 3, solubility: > 250000 nM
Compound 3 ended at the assay's limit (the forecaster's own chance of this, stated with the estimate: 10%); middle value at least 2.5-fold (0.39 log units) away from the limit.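

This place on the chain is not silent in this assay: hydroxy in place of methyl on a saturated chain carbon, two bonds along the chain from a double-bonded nitrogen, gives an at least 3.1-fold higher number from compound 1 to compound 3 (0.50 log units; beyond the scatter). The only earlier step was flat and lay elsewhere on the shared core, so this is the first single change shown that moves the read-out beyond the scatter. Compound 3 gives > 250000 nM, which is a limit of the assay and not a number, so the step has a floor but no known size: the limit of > 250000 nM in this assay, at which 1 of the 3 values shown sits.

Still open, going by these compounds, is whether an amine, a carboxylic acid or a longer chain ending in hydroxy at this place would reach the same limit. On these data alone, it is also open whether the same change would carry over to the core of compound 2.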